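Thiol Side-Chain Variation on a Pyrazolopyrimidine Series

The compounds below may be only part of what the source reports. "The series", "measured", "known", "first", "only" and "open" are said of these compounds alone.

Compound 1 `CC(C)c1n[nH]c2c(NCc3ccc(-c4ccccn4)cc3)nc(SCC(O)CO)nc12` in a functional assay on HT cells (Homo sapiens) for antiproliferative activity, read by fluorescence, with a stated time of 72 h (a higher number here means a weaker inhibitor of growth, a lower number a stronger inhibitor of growth), gives 21 nM.
Compound 2 `CC(C)c1n[nH]c2c(NCc3ccc(-c4ccccn4)cc3)nc(SC[C@H](O)CN)nc12` in this assay gives 63 nM.

Compound 2 has the highest number of the two, with compound 1 the nearer neighbour. Compound 3 `CCC(CO)Sc1nc(NCc2ccc(-c3ccccn3)cc2)c2[nH]nc(C(C)C)c2n1` differs from compound 2 by 1-(hydroxymethyl)propyl in place of 3-amino-2-hydroxypropyl on a sulfur. Among the compounds with values here, the only measured step at this sulfur chain, a 3.0-fold higher number from compound 1 to compound 2 (0.48 log units; beyond the scatter), bears on it and shows that one group entering there moved the number modestly. With the 3-amino-2-hydroxypropyl leaving, a modest movement back toward the number of compound 1 is expected in this assay. Compound 3 is therefore expected to give 35 nM (range 12 nM to 110 nM). The estimated step is a 1.8-fold lower number from compound 2 to compound 3 (0.26 log units; within the scatter).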

Compound 3, concentration for 50% growth inhibition: 255 nM
Compound 3: middle estimate off by 7.3-fold (0.86 log units), on the low side; measured number outside the range, above it.
By their numbers in this assay, from the lowest: compound 1; then compound 2; then compound 3.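

Within the data shown here, the sulfur chain can shift this number much further than the earlier pair showed: 1-(hydroxymethyl)propyl gives a 4.0-fold higher number from compound 2 to compound 3 (0.61 log units; beyond the scatter) and also a 12-fold higher number from compound 1 to compound 3 (1.08 log units; beyond the scatter) in this assay and the second of these steps is large, where the only earlier step was modest. Of the three chains, 1-(hydroxymethyl)propyl gives the weakest growth inhibition. Nothing available explains this shift.

Which feature of the 1-(hydroxymethyl)propyl chain accounts for the loss stays open. So does how a carboxylic acid or a longer chain on this sulfur would read.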